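The compounds below may be only part of what the source reports. "The series", "measured", "known", "first", "only" and "open" are said of these compounds alone.

Measured in a functional assay on thoracic aorta (strain Wistar) for inhibition, with Aorta (Rattus norvegicus) as the target, in the presence of a further agent that is not named here; on this read-out higher numbers stand for an effect only at larger amounts of compound and lower numbers for an effect already at smaller amounts:
- Compound 1 `O=C1OC(C(O)CO)C(OCCCCCCO[N+](=O)[O-])=C1O`: > 100000 nM
- Compound 2 `O=C1OC(C(O)CO)C(OCCCCC(CO[N+](=O)[O-])O[N+](=O)[O-])=C1O`: > 100000 nM

Compound 1 stands at > 100000 nM, which is a limit of the assay and not a number. Compound 2 gives > 100000 nM, which is also a limit. The picture so far is therefore (the limit of > 100000 nM in this assay, at which 2 of the 2 values shown sit).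

Compound 3 `O=C1OC(C(O)CO)C(OCCCO[N+](=O)[O-])=C1O` keeps the shared core and differs from compound 1 as follows: nitrooxy in place of 3-(nitrooxy)propyl on a saturated chain carbon, three bonds along the chain from an oxygen on an unsaturated carbon. This places nitrooxy in place of 3-(nitrooxy)propyl on a saturated chain carbon, three bonds along the chain from an oxygen on an unsaturated carbon.

Among the compounds with values here, the only measured step is a step that the two limits leave unreadable from compound 1 to compound 2. It is a different change and has no readable size, so it offers no size to carry over. With no evidence for a shift in either direction, the expected result in this assay is no real change, which is an expectation only. The estimated step is a step that the limit leaves unreadable from compound 1 to compound 3. For compound 3 the estimated value is 120000 nM, with an expected range of 40000 nM to 400000 nM.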

Compound 3, half-maximal effective concentration in the Aorta assay: > 100000 nM
Compound 3 gave a limit, no number; the forecaster's own chance of this, stated with the estimate: 70%; the middle value lies beyond the limit too.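

In the Aorta assay compound 1 gives > 100000 nM as a limit and not a number. In the Aorta assay compound 3 gives > 100000 nM as a limit and not a number. No step between these two compounds can be read, and the picture stays as follows: the limit of > 100000 nM in the Aorta assay, at which 3 of the 3 values shown sit.

In a physicochemical assay for acid dissociation, compound 1 gives 7.6 and compound 3 gives 7.55 with the two values within the scatter of each other.

The compounds shown leave open whether any nitrooxy-bearing chain on the shared core gives a measurable effect in the Aorta assay at all.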